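Furan-2-yl for benzyl: a repeated change on two cores

This account rests on a few compounds, and the source may have more. Where it says the series, first, only, none or still open, it means among the compounds named here.

Measured compounds:
compound 1 `Nc1nc(Cc2ccccc2)nc2cn(-c3ccccc3O)nc12` gives 19% in an assay on CHO cells for displacement of a labelled ligand from adenosine receptor A3 (Homo sapiens), read by scintillation counting, with a stated time of 60 min, tested at 1 uM; on this read-out higher numbers stand for more inhibition at the one concentration tested (going by the name of the read-out) and lower numbers for less inhibition
compound 2 `Nc1nc(-c2ccco2)nc2cn(-c3ccccc3O)nc12` gives 36% in this assay
compound 3 `Nc1nc(Cc2ccccc2)nc2cn(Cc3ccccc3)nc12` gives 15% in this assay

Compound 4 `Nc1nc(-c2ccco2)nc2cn(Cc3ccccc3)nc12` has not yet been measured in this assay. It is the compound 3 counterpart of the pair formed by compound 1 and compound 2: the change is the same one, (furan-2-yl in place of benzyl on an aromatic carbon), and on compound 1 it reads (furan-2-yl in place of benzyl on an aromatic carbon). That change is seen once with a measured outcome and will occur twice once compound 4 is read. Its measured step is a number 17 percentage points higher from compound 1 to compound 2 (beyond the scatter).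

The two cores differ by benzyl in place of 2-hydroxyphenyl on an aromatic nitrogen. That difference on its own produced a number 4 percentage points lower from compound 1 to compound 3 (within the scatter), so compound 1 and compound 3 give numbers that are not told apart by this read-out. Compound 2 stands apart from both: its value exceeds that of compound 3 by more than the scatter, and the step from compound 1 is also beyond it.

For compound 4 the step of a number 15 percentage points higher from compound 3 to compound 4 (beyond the scatter) is expected to be of similar size to the earlier one, because the change is the same and compound 3 with 15% starts close to where compound 1 started. The expected value of compound 4 in this assay is 30%, estimated to fall between 15% and 45%. The estimate rests on a single measured instance of the change and on one core difference, so the expectation is a working one.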

Compound 4, a percentage reported as inhibition, at one concentration (the size of the read-out at that concentration, not a potency): 2%
Beside the measured number, compound 4's estimate is 28 percentage points above it; measured number outside the range, below it.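

On the core of compound 3, furan-2-yl in place of benzyl on an aromatic carbon gives a number 13 percentage points lower from compound 3 to compound 4 (beyond the scatter) in this assay, so the direction of this change does not carry over from the core of compound 1: the same change on two cores in this assay, a number 17 percentage points higher (beyond the scatter) from compound 1 to compound 2 and a number 13 percentage points lower (beyond the scatter) from compound 3 to compound 4, 30 percentage points apart, beyond the scatter of two such steps. Read across the other edge of the same four compounds, benzyl in place of 2-hydroxyphenyl on an aromatic nitrogen gives a number 34 percentage points lower from compound 2 to compound 4 (beyond the scatter), whereas the same swap could not be told apart from scatter when made between compound 1 and compound 3: the same change on two cores in this assay, a number 4 percentage points lower (within the scatter) from compound 1 to compound 3 and a number 34 percentage points lower (beyond the scatter) from compound 2 to compound 4, 30 percentage points apart, beyond the scatter of two such steps. The two changes therefore do not add up independently in these compounds, but a single set of four compounds, read at one concentration as inhibition and not as potency, shows neither how general this is nor why it happens.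

The compounds shown leave open whether the difference between the cores lies with the hydroxyl of the 2-hydroxyphenyl group or with the ring itself, which a plain phenyl or a 2-methoxyphenyl on the aromatic nitrogen would separate. Also open, from the compounds shown here alone, is whether the opposite steps are particular to furan-2-yl, which thiophen-2-yl or a phenethyl chain on the aromatic carbon would test on both cores.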